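Replacing the 4-fluorophenyl group of compound 2

The source may hold more compounds than are shown below. What is called first, only, known or untested is meant among the compounds shown, and "the series" means these compounds.

Compound 1 `Cn1cc(C2CC(c3ccc(F)cc3)=NN2C(=O)c2cccnc2)c2cc(Br)ccc21` gives 480 nM as measured
Compound 2 `COc1ccc2c(c1)c(C1CC(c3ccc(F)cc3)=NN1C(=O)c1ccc(OC)nc1)cn2C` gives 220 nM as measured

Both numbers come from a functional assay on HepG2 cells (Homo sapiens) for inhibition, read by MTT assay, with a stated time of 48 h (on this read-out higher numbers stand for weaker inhibition of growth and lower numbers for stronger inhibition of growth), and compound 2 stands lowest of the two at 220 nM with a gap to compound 1 that lies beyond the scatter. The two compounds differ in more than one place, so their gap says nothing about any single change.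

The next compound is compound 3 `COc1ccc2c(c1)c(C1CC(c3cc(OC)c(OC)c(OC)c3)=NN1C(=O)c1ccc(OC)nc1)cn2C` which keeps everything else in compound 2. Within the data shown here, it has 3,4,5-trimethoxyphenyl in place of 4-fluorophenyl on a carbon with a double bond to nitrogen and no measured step between one-place neighbours bears on this exchange.

With so little to go on, only a small move toward a lower number is expected in this assay and nothing beyond the scatter. The estimate amounts to a 1.2-fold lower number from compound 2 to compound 3 (0.09 log units; within the scatter) as the expected step. Compound 3 is expected at 180 nM with an estimated range from 60 nM to 550 nM for its measurement.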

Compound 3, concentration for 50% growth inhibition: > 10000 nM
Compound 3 ended at the assay's limit; the forecaster's own chance of this, stated with the estimate: 3%; middle value at least 55-fold (1.74 log units) from the limit.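

Compound 3 stands at > 10000 nM in this assay, and this value is a limit of the assay, not a number. The group on the carbon with a double bond to nitrogen of the five-membered ring therefore matters greatly: 3,4,5-trimethoxyphenyl in place of 4-fluorophenyl gives an at least 45-fold higher number from compound 2 to compound 3 (1.65 log units; beyond the scatter), the only one-place step among the compounds shown and one well beyond the scatter. The entering group has 12 heavy atoms against 7 and 3 hydrogen-bond acceptors against 0, but a single exchange cannot separate these differences, and the step gives only a bound on the change: the limit of > 10000 nM in this assay, at which 1 of the 3 values shown sits.

On these data alone, it remains open whether a plain phenyl, a phenyl with a single methoxy group, or a phenyl with chlorine in place of the fluorine would stay close to compound 2 or fall away as compound 3 does. As far as these compounds go, it is also open whether the same exchange would act alike on the core of compound 1, and which of the several differences between compound 1 and compound 2 accounts for the gap between them.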